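Cytotoxicity outlook for a dimethoxyphenyl analogue

A few compounds are considered here, and "the series" means these few. Any claim that something is new, unique, unknown or untested is made for them only; others in the source may bear on it.

Compound 2 `CCOC(=O)CCCCCOc1cccc(CN(C(=O)c2ccc(-c3cccc(-c4nnc(C)o4)c3)cc2)C(C)C)c1` carries a 3-(5-methyl-1,3,4-oxadiazol-2-yl)phenyl arm on the shared core. In an ADME assay on HEK293 cells (Homo sapiens) for cytotoxicity, read by CellTiter-Glo and resazurin assay, with a stated time of 72 h (on this read-out lower numbers stand for an effect already at smaller amounts and higher numbers for an effect only at larger amounts of compound), compound 2 gives > 26000 nM, which is a limit of the assay rather than a measured number. Its closest measured relative, compound 1 `CCOC(=O)CCCCCOc1cccc(CN(C(=O)c2ccc(-c3cccc(NC(C)=O)c3)cc2)C(C)C)c1`, differs only in bearing an acetamido group where the oxadiazole sits. In this assay compound 1 gives > 26000 nM, again a limit. The step that the two limits leave unreadable from compound 1 to compound 2 is therefore unreadable, as both values sit at the same ceiling; this is summed up by the limit of > 26000 nM in this assay, at which 2 of the 2 values shown sit.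

Compound 3 `CCOC(=O)CCCCCOc1cccc(CN(C(=O)c2ccc(-c3cc(OC)cc(OC)c3)cc2)C(C)C)c1` is not yet measured. It differs from compound 2 by 3,5-dimethoxyphenyl in place of 3-(5-methyl-1,3,4-oxadiazol-2-yl)phenyl on an aromatic carbon. Among the compounds with values here, no measured step bears directly on such a swap, and the only measured step, from one arm to another, shows no change that can be read. With both known values sitting at the limit, compound 3 is expected to behave alike, and its value in this assay is estimated at 30000 nM, within a range from 15000 nM to 60000 nM, most likely reported once more as a limit. The step this estimate implies, a step that the limit leaves unreadable from compound 2 to compound 3, is expected to be nothing beyond the usual scatter.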

Compound 3, half-maximal effective concentration: > 26000 nM
Compound 3 was reported as a limit (the forecaster's own chance of this, stated with the estimate: 80%); the middle value is on the limit's open side.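

In this assay compound 3 gives > 26000 nM, which is again a limit of the assay and not a number. The steps among compound 1, compound 2 and compound 3 therefore cannot be read, and all three compounds share one limit: the limit of > 26000 nM in this assay, at which 3 of the 3 values shown sit. On these data alone, whether their three arms differ in effect stays open, with no exact value shown for any of them.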